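A few compounds are considered here, and "the series" means these few. Any claim that something is new, unique, unknown or untested is made for them only; others in the source may bear on it.

Measured compounds in a physicochemical assay for lipophilicity; a higher number here means a more lipophilic compound, a lower number a more polar compound:

Compound 1, `C=CCc1ccc(OC(=O)c2ccccn2)c(OC)c1`, gives 0.86.
Compound 2, `C=CCc1ccc(OC(=O)c2ccc(C)cc2)c(OC)c1`, gives 2.87.
Compound 3, `C=CCc1ccc(OC(=O)c2ccccc2F)c(OC)c1`, gives 2.7.

All three share one core and differ only in the aromatic ring attached to the carbonyl carbon. Compound 3 stands second highest of the three numbers, lying a number 0.17 log units lower from compound 2 to compound 3 (within the scatter), so compounds 2 and 3 cannot be told apart on this assay, while it sits far above compound 1, as a number 1.84 log units higher from compound 1 to compound 3 (beyond the scatter) shows.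

Compound 4, `C=CCc1ccc(OC(=O)c2cccc(C)c2)c(OC)c1`, has not yet been measured. It differs from compound 3 in one place:

3-methylphenyl in place of 2-fluorophenyl on a carbonyl carbon

Going by the values given here, the steps that bear on this change are a number 2.01 log units higher from compound 1 to compound 2 (beyond the scatter) and a number 1.84 log units higher from compound 1 to compound 3 (beyond the scatter), both large, together with a number 0.17 log units lower from compound 2 to compound 3 (within the scatter), which is small. The 4-methylphenyl ring of compound 2 and the 2-fluorophenyl ring of compound 3 thus give numbers within the scatter of each other, and the 3-methylphenyl ring of compound 4 carries the same atom count with no donors or acceptors. A step of a number 0.15 log units higher from compound 3 to compound 4 (within the scatter) is therefore expected, not beyond the scatter. Compound 4 is estimated at 2.85, with a range from 2.5 to 3.2.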

Compound 4, partition coefficient: 2.87
Beside the measured number, compound 4's estimate is 0.02 log units below it; measured number inside the range.
By their numbers in this assay, from the lowest: compound 1; then compounds 3, 2 and 4 (each within the scatter of the next).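

In this assay, replacing the 4-methylphenyl ring with the 3-methylphenyl ring on the carbonyl carbon gives no change at the digits printed from compound 2 to compound 4 (within the scatter), so these two methylphenyl rings cannot be told apart here. The 2-fluorophenyl ring cannot be separated from the 3-methylphenyl ring either, with a number 0.17 log units higher from compound 3 to compound 4 (within the scatter), while the pyridin-2-yl ring again stands well apart, with a number 2.01 log units higher from compound 1 to compound 4 (beyond the scatter); three different carbon-only aromatic rings now give values within the scatter of one another, and only compound 1 falls outside that group. No measurement at hand offers an explanation for this pattern.

Going by these compounds, it remains open whether a ring carrying an amine, a carboxylic acid or a longer chain such as butyl at this place would stay with compound 2, compound 3 and compound 4 or fall closer to compound 1. The same question applies to a phenyl ring bearing a hydroxyl group.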